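The compounds below may be only part of what the source reports. "The series", "measured", "known", "first", "only" and "open" are said of these compounds alone.

Of the compounds shown here, two from one series have been measured in an assay on isolated protein for inhibition of aldehyde dehydrogenase 1A1 (Homo sapiens), read by spectrophotometry, tested at 10 uM; on this read-out lower numbers stand for less inhibition and higher numbers for more inhibition at the one concentration tested (going by the name of the read-out). Compound 1 `Cc1cccc(Cn2c(CN3CCN(C(=O)c4ccc([N+](=O)[O-])cc4)CC3)nc3ccccc32)c1` gives 24.3%, while compound 2 `O=C(C1CC1)N1CCN(Cc2nc3ccccc3n2Cc2ccccc2F)CC1` gives 40.7%, the higher of the two numbers, with a gap to compound 1 that lies beyond the usual scatter. Compound 3 `O=C(C1CC1)N1CCN(Cc2nc3ccccc3n2CC2CCCC2)CC1` has not yet been measured; it differs from compound 2 by cyclopentyl in place of 2-fluorophenyl on a saturated chain carbon bound to an aromatic nitrogen. For the measured compounds named here, no measured pair shows the effect of such a change. Compound 3 is nevertheless expected to sit a little lower, the step being a number 7.7 percentage points lower from compound 2 to compound 3 (within the scatter), which need not exceed the scatter. Compound 3 is therefore estimated at 33%, within 15% to 50%.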

Compound 3, a percentage reported as inhibition, at one concentration (the size of the read-out at that concentration, not a potency): 44.5%
Compound 3: the middle estimate sits 11.5 percentage points below what was measured, within the range that was stated.
By their numbers in this assay, from the lowest: compound 1; then compounds 2 and 3 (each within the scatter of the next).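

In this assay, cyclopentyl in place of 2-fluorophenyl on a saturated chain carbon bound to an aromatic nitrogen gives a number 3.8 percentage points higher from compound 2 to compound 3 (within the scatter). In this one pair, then, the aromatic ring with its fluorine is not required at this position to keep the read-out, since a non-aromatic ring of carbon only serves equally within the scatter. Nothing available explains this result. As far as these compounds go, it remains open how an open-chain group such as n-butyl, an amine or a carboxylic acid would read at this place.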